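Aryl hydrazone series: bromo for trifluoromethyl on compound 1

The compounds below may be only part of what the source reports. "The series", "measured", "known", "first", "only" and "open" are said of these compounds alone.

Measured compounds and values in a functional assay on A549 cells (Homo sapiens) for inhibition, read by MTT assay, with a stated time of 48 h; a lower number here means a stronger inhibitor, a higher number a weaker inhibitor:
compound 1, `Fc1ccc(/C=N/Nc2nc(-c3ccc(C(F)(F)F)cc3)cs2)cc1F`, gives 2610 nM
compound 2, `COc1ccccc1-c1csc(N/N=C/c2cc(Br)c(OC)c(OC)c2)n1`, gives 94900 nM
compound 3, `COc1cc(/C=N/Nc2nc(-c3ccc(F)c(F)c3)cs2)cc(Br)c1OC`, gives 21100 nM

Going by the values given here, compound 1 stands lowest of the three numbers in this assay; the nearest is compound 3, which differs from it in both aryl groups and so has no single-place step to it, and the furthest is compound 2.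

The compound still to be measured is compound 4, `Fc1ccc(/C=N/Nc2nc(-c3ccc(Br)cc3)cs2)cc1F`. It differs from compound 1 in one place: bromo in place of trifluoromethyl on an aromatic carbon.

Among the compounds with values here, the only single-place step so far is a 4.5-fold lower number from compound 2 to compound 3 (0.65 log units; beyond the scatter), which concerns the aryl group on the core but exchanges a different pair of groups, so it bears on the present change only loosely: it shows that changes of this aryl group move the number by modest amounts. Nothing directly tests bromo against trifluoromethyl. A small step is therefore expected in this assay, with direction uncertain and more likely toward a somewhat higher number; the expected step is a 1.5-fold higher number from compound 1 to compound 4 (0.19 log units; within the scatter). For compound 4 the estimate is 4000 nM, within 1500 nM to 12000 nM.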

Compound 4, half-maximal inhibitory concentration: > 100000 nM
Compound 4: only a limit was reported (the forecaster's own chance of this, stated with the estimate: 5%); middle value at least 25-fold (1.39 log units) away from the limit.
By their numbers in this assay, from the lowest: compound 1; then compound 3; then compound 2. At a limit, above all of these: compound 4.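

In this assay, going by these compounds alone, bromo in place of trifluoromethyl gives an at least 38-fold higher number from compound 1 to compound 4 (1.58 log units; beyond the scatter), far larger than the only earlier step on the aryl group of the core, a 4.5-fold lower number from compound 2 to compound 3 (0.65 log units; beyond the scatter). Within the data shown here, at this place, on an aromatic carbon para to a large group, a single-group exchange can therefore move the number much further than the earlier compounds indicated, and bromo and trifluoromethyl are not interchangeable here. The value of compound 4 is a limit of the assay and not a number, so the step has no upper end: the limit of > 100000 nM in this assay, at which 1 of the 4 values shown sits.

On these data alone, with only these two groups compared at this place, it stays open whether a chloro or a nitrile group would keep the number of compound 1. The cause of the loss also stays open, as nothing shown measures it.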